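The compounds below may be only part of what the source reports. "The series", "measured", "known", "first", "only" and "open" are said of these compounds alone.

Among the compounds with values here, in a functional assay on OVCAR-3 cells (Homo sapiens) for inhibition, read by MTT assay, with a stated time of 24 h (a higher number here means a weaker inhibitor, a lower number a stronger inhibitor), compound 2 `CC1(C)[C@H]2CC[C@]1(C)N(Cc1cn(-c3ccccc3C#N)nn1)C(=O)C2` gives 110 nM, the lower of the two numbers measured so far, and compound 1 `CC1(C)[C@H]2CC[C@]1(C)N(Cc1cn(-c3cccc(F)c3)nn1)C(=O)C2` gives 430 nM. Compound 3 `CC1(C)[C@H]2CC[C@]1(C)N(Cc1cn(-c3cccc(C#N)c3)nn1)C(=O)C2` carries one change from compound 2: 3-cyanophenyl in place of 2-cyanophenyl on an aromatic nitrogen. Within the data shown here, the only measured step at that nitrogen is a 3.9-fold lower number from compound 1 to compound 2 (0.59 log units; beyond the scatter), a modest one beyond the scatter, and it swaps the group itself, so it does not show what moving the nitrile alone does. A modest rise in this assay is therefore expected, an estimated 2.0-fold higher number from compound 2 to compound 3 (0.30 log units; within the scatter). The estimate for compound 3 is 220 nM, within an expected range of 70 nM to 650 nM.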

Compound 3, half-maximal inhibitory concentration: 230 nM
Compound 3: middle estimate off by 1.0-fold (0.02 log units), on the low side; low and high end bracket the measured number.
By their numbers in this assay, from the lowest: compound 2; then compounds 3 and 1 (each within the scatter of the next).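

In this assay, moving the nitrile alone, with the same atoms joined differently, gives a 2.1-fold higher number from compound 2 to compound 3 (0.32 log units; beyond the scatter), so the place of the nitrile on the phenyl ring counts here. Cyano in place of fluoro on the aromatic carbon gives a 1.9-fold lower number from compound 1 to compound 3 (0.27 log units; within the scatter), so compound 1 and compound 3 cannot be told apart, and the nitrile alone does not account for the low number of compound 2. Nothing available here explains the difference between the two nitrile placements.

On these data alone, what stays open is how 4-cyanophenyl and 2-fluorophenyl would read. As far as these compounds go, the effect of an amine or a carboxylic acid on the phenyl ring also remains unknown.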